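Tail chain of compound 1: swapping the vinyl end

The source may report more compounds than this note shows. Statements on the series, on what has been measured and on what is new or still open speak of the compounds shown alone.

Measured compounds:
compound 1, `C=CCCn1c(=O)c2[nH]cnc2n(CCC)c1=O`: 200 nM in a functional assay (trachea) with Cavia porcellus as the target; a higher number here means that more compound is needed for the effect, a lower number that less compound is needed
compound 2, `CCCn1c(=O)n(CCC#N)c(=O)c2[nH]cnc21`: 1700 nM
compound 3, `CCCn1c(=O)n(CCN(C)C)c(=O)c2[nH]cnc21`: 2700 nM

Compound 1 gives the lowest number of the three; its nearest neighbour is compound 2 and the furthest is compound 3, both beyond the scatter. The two steps that exchange the vinyl end of the tail read an 8.5-fold higher number from compound 1 to compound 2 (0.93 log units; beyond the scatter) and a 14-fold higher number from compound 1 to compound 3 (1.13 log units; beyond the scatter), while a 1.6-fold higher number from compound 2 to compound 3 (0.20 log units; within the scatter), so the two replacements land close to each other.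

Compound 4, `CCCn1c(=O)n(CCCCC(C)=O)c(=O)c2[nH]cnc21`, is not yet measured. Its difference from compound 1 is 2-acetylethyl in place of vinyl on a saturated chain carbon, two bonds along the chain from an aromatic nitrogen. The two measured steps away from compound 1 bear on this change, since each puts a group carrying a heteroatom in place of the vinyl at the same place on the chain, and each raised the number well beyond the scatter. A rise of similar size is therefore expected for compound 4, with the longer chain adding some uncertainty. Compound 4 is expected to give about 1400 nM, within a range of 450 nM to 4500 nM. The step expected for compound 4 is a 7.0-fold higher number from compound 1 to compound 4 (0.85 log units; beyond the scatter).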

Compound 4, half-maximal effective concentration: 60 nM
Beside the measured number, compound 4's estimate is 23-fold (1.37 log units) above it, outside the stated range (below it).
By their numbers in this assay, from the lowest: compound 4; then compound 1; then compounds 2 and 3 (each within the scatter of the next).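

In this assay a heteroatom at the end of this tail does not by itself raise the number: 2-acetylethyl in place of vinyl gives a 3.3-fold lower number from compound 1 to compound 4 (0.52 log units; beyond the scatter) and so goes against the rise seen with compound 2 and compound 3. Measured against those two replacements, the same position shows much larger steps, a 28-fold lower number from compound 2 to compound 4 (1.45 log units; beyond the scatter) and a 45-fold lower number from compound 3 to compound 4 (1.65 log units; beyond the scatter), so the ends tried here no longer land close together. Compound 4 now has the lowest number of the four, with its steps to all the others beyond the scatter.

No measured evidence accounts for this reversal. Still open, as far as these compounds go, is whether the drop follows the carbonyl or the longer chain, which a plain alkyl chain of the same length or a hydroxyl end at this place would help separate.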